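This account rests on a few compounds, and the source may have more. Where it says the series, first, only, none or still open, it means among the compounds named here.

Working notes on the series.

Of the compounds shown here, three have been measured in an assay for inhibition of hexokinase-2 (Homo sapiens), read by coupled enzyme assay, with a stated time of 10 min, in the presence of a further agent that is not named here; on this read-out higher numbers stand for weaker inhibition and lower numbers for stronger inhibition. Compound 1 `C=C1CC[C@H]2[C@@](C)(CCC(=O)N[C@@]2(C)COC(=O)c2ccccc2)[C@@H]1/C=C/C1=CCOC1=O` carries a benzoate ester; in this assay compound 1 gives > 50000 nM, which is a limit of the assay and not a number. Compound 2 `C=C1CC[C@H]2[C@@](C)(CCC(=O)N[C@@]2(C)COC(=O)[C@H](N)CC(C)C)[C@@H]1/C=C/C1=CCOC1=O` differs from it by 1-amino-3-methylbutyl in place of phenyl on a carbonyl carbon; in this assay compound 2 gives > 50000 nM, again a limit. Among the measured compounds shown here, the one step between measured compounds, a step that the two limits leave unreadable from compound 1 to compound 2, therefore cannot be read. Compound 3 `C=C1CC[C@H]2[C@@](C)(CC[C@@H](O)[C@@]2(C)NC=O)[C@@H]1/C=C/C1=CCOC1=O`, with a free hydroxyl and a formamide on the shared core, in this assay gives > 50000 nM, also a limit. Compound 3 thus stands where every measured value stands, at the limit of > 50000 nM in this assay, at which 3 of the 3 values shown sit, so no ordering among compounds 1, 2 and 3 is possible.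

Compound 4 `C=C1CC[C@H]2[C@@](C)(CC[C@@H](OC(=O)CCCC[C@@H]3CCSS3)[C@@]2(C)NC=O)[C@@H]1/C=C/C1=CCOC1=O` differs from compound 3 by a group of 11 heavy atoms (8 carbon, 1 oxygen, 2 sulfur; one five-membered non-aromatic ring with 2 hetero atoms) in place of a hydrogen atom, on an oxygen on a saturated carbon. For the measured compounds named here, no measured step bears on this change, and none of the measured steps is readable. The expected step is a number no higher from compound 3 to compound 4 (the limit leaves the size open), nothing beyond the scatter, most probably another limit. For compound 4 the estimate in this assay is 50000 nM, with a range from 20000 nM to 150000 nM.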

Compound 4, half-maximal inhibitory concentration: > 50000 nM
Compound 4 ended at the assay's limit; the forecaster's own chance of this, stated with the estimate: 85%; the middle value sits exactly at the limit.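

Compound 3 and compound 4 both sit at a limit of this assay, not at a number, so the step between them cannot be read. The compounds shown leave open how they rank and whether any change to the shared core gives a measurable value: the limit of > 50000 nM in this assay, at which 4 of the 4 values shown sit.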